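This account rests on a few compounds, and the source may have more. Where it says the series, first, only, none or still open, it means among the compounds named here.

In a functional assay on DU-145 cells (Homo sapiens) for inhibition, read by trypan blue exclusion, with a stated time of 72 h (on this read-out higher numbers stand for weaker inhibition and lower numbers for stronger inhibition), compound 1 (`COc1ccc(Nc2ncc3cc(S(=O)(=O)c4ccc(Cl)cc4)c(=O)n(C)c3n2)cc1`) gives 30000 nM and compound 3 (`Cn1c(=O)c(S(=O)(=O)c2ccc(F)cc2F)cc2cnc(Nc3ccncn3)nc21`) gives 50000 nM. Compound 2 (`Cn1c(=O)c(C(=O)Nc2ccc(F)cc2)cc2cnc(Nc3ccc4[nH]ccc4c3)nc21`) gives 5000 nM, the lowest of the three numbers and beyond the scatter from both others. Compound 4 (`Cc1ccc(S(=O)(=O)c2cc3cnc(Nc4ccc5[nH]ccc5c4)nc3n(C)c2=O)cc1`), not yet measured, has (4-methylphenyl)sulfonyl in place of (4-fluorophenyl)carbamoyl on an aromatic carbon of compound 2: (4-methylphenyl)sulfonyl in place of (4-fluorophenyl)carbamoyl on an aromatic carbon. Within the data shown here, no measured pair isolates this change. Compound 1 and compound 3 also carry a sulfonyl group, though they differ from compound 4 elsewhere, and both stand higher than compound 2. A moderate upward step beyond the scatter is therefore expected in this assay, estimated as a 2.4-fold higher number from compound 2 to compound 4 (0.38 log units; beyond the scatter). Compound 4 is expected at 12000 nM, with an estimated range of 4000 nM to 35000 nM.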

Compound 4, half-maximal inhibitory concentration: 750 nM
Compound 4: middle estimate off by 16-fold (1.20 log units), on the high side; measured number below the stated range.
By their numbers in this assay, from the lowest: compound 4; then compound 2; then compounds 1 and 3 (each within the scatter of the next).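

In this assay, (4-methylphenyl)sulfonyl in place of (4-fluorophenyl)carbamoyl on this aromatic carbon gives a 6.7-fold lower number from compound 2 to compound 4 (0.82 log units; beyond the scatter) with the rest of compound 4 unchanged, so here the sulfonyl group goes with the lower number. The higher numbers of compound 1 and compound 3, which differ elsewhere, therefore cannot be read as a penalty of the sulfonyl group at this position. No available evidence explains the step. From the compounds shown here alone, whether the step follows the sulfonyl link or the change from fluorine to methyl on the phenyl ring stays open. So does how an amine or a carboxylic acid in place of that methyl would read.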